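This account rests on a few compounds, and the source may have more. Where it says the series, first, only, none or still open, it means among the compounds named here.

Measured so far:
compound 2, `CC(=O)n1nc(C)c(-c2ccc(Cl)c(Cl)c2)c1N`: 8400 nM
compound 1, `Cc1[nH]nc(N)c1-c1cccc(OC(F)(F)F)c1`: > 100000 nM

Among the measured compounds shown here, in an assay on Sf9 cells for inhibition of mitogen-activated protein kinase kinase kinase 14 (Homo sapiens), read by ADP-Glo, with a stated time of 60 min (on this read-out lower numbers stand for stronger inhibition and higher numbers for weaker inhibition), compound 2 gives 8400 nM, the only plain number among the values shown. Compound 1 is reported only as a limit, > 100000 nM, so it sets no number of its own. For the measured compounds named here, compound 2 therefore stands alone as the one compound with a measured strength, and there is no measured pair of close relatives from which the size of a single change could be read off.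

Compound 3, `Cc1nn(C(=O)C2CCC2)c(N)c1-c1ccc(Cl)c(Cl)c1`, is the compound still to be measured. It differs from compound 2 in one place: cyclobutyl in place of methyl on a carbonyl carbon. Going by the values given here, with no measured step of this kind to lean on, the expectation is for a change no larger than the scatter, in either direction. Compound 3 is estimated at 6000 nM, with a range from 1500 nM to 25000 nM, which is a step of a 1.4-fold lower number from compound 2 to compound 3 (0.15 log units; within the scatter) and is expected to stay close to compound 2.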

Compound 3, half-maximal inhibitory concentration: 2900 nM
The estimate for compound 3 lay 2.1-fold (0.32 log units) above the measured number; measured number inside the range.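

Among the compounds shown here, the carbonyl carbon is the first place where the effect of a single change can be read, and in this assay replacing methyl with cyclobutyl gives a 2.9-fold lower number from compound 2 to compound 3 (0.46 log units; beyond the scatter). The ring's extra carbons are therefore accepted at this position, at least in this one pair, and the number moves in the direction of stronger inhibition, though compound 3 remains a modest inhibitor. Nothing among the data shown accounts for this modest step.

A single step cannot show whether the ring itself matters or whether added carbon alone would do the same, a question that an open chain such as butyl on the same carbonyl carbon would address. It also leaves open how a smaller cyclopropyl, a larger cyclohexyl or a ring carrying an amine would fare there.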